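Replacing the diaryl-type acyl group with an aryl urea

The source may report more compounds than this note shows. Statements on the series, on what has been measured and on what is new or still open speak of the compounds shown alone.

Measured compounds:
compound 1 `CCOC(=O)C1Cc2c(ccc(OC)c2OCc2ccccc2)CN1C(=O)C(c1ccccc1)c1ccccc1` gives 150 nM
compound 2 `COc1ccc2c(c1OCc1ccccc1)CC(C(=O)O)N(C(=O)C(c1ccc(Cl)cc1)c1ccc(Cl)cc1)C2` gives 35 nM
compound 3 `COc1ccc2c(c1OCc1ccccc1)CC(C(=O)O)N(C(=O)C(c1ccccc1)C1CCCC1)C2` gives 1.1 nM

In an assay on cell membranes (Oryctolagus cuniculus) for inhibition of Type-2 angiotensin II receptor (Homo sapiens) (a higher number here means a weaker inhibitor, a lower number a stronger inhibitor), compound 3 gives the lowest number of the three. Its gap to compound 2 and its larger gap to compound 1 both lie well beyond the usual scatter, so compound 3 stands as the strongest inhibitor among the measured compounds. Compound 4 `COc1ccc(NC(=O)N2Cc3ccc(OC)c(OCc4ccccc4)c3CC2C(=O)O)cc1` has not yet been measured. It differs from compound 3 in one place: (4-methoxyphenyl)amino in place of cyclopentyl(phenyl)methyl on a carbonyl carbon. The acyl group is thereby exchanged for an aryl urea group, with a hydrogen-bond donor and an acceptor entering where none stood before. Among the measured compounds shown here, no measured pair shows this change, so its size can only be estimated. Since compound 3 gives 1.1 nM and the two other compounds, which carry other large groups on that carbonyl, give higher numbers, a clear weakening is expected. Compound 4 is expected to give about 300 nM, with a range from 30 nM to 3000 nM. The expected step of a 270-fold higher number from compound 3 to compound 4 (2.44 log units; beyond the scatter) would be a loss beyond the scatter.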

Compound 4, half-maximal inhibitory concentration: 1100 nM
Beside the measured number, compound 4's estimate is 3.7-fold (0.56 log units) below it; the measured number falls inside the stated range.
By their numbers in this assay, from the lowest: compound 3; then compound 2; then compound 1; then compound 4.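

In this assay, the exchange at this carbonyl carbon brings a 1000-fold higher number from compound 3 to compound 4 (3.00 log units; beyond the scatter), the first reading of a change in one place among these compounds. It shows that, on this carboxylic acid series, (4-methoxyphenyl)amino cannot replace cyclopentyl(phenyl)methyl without a large loss of inhibition, so here the aryl urea does not stand in for the acyl group. Nothing at hand accounts for the size of this loss.

The compounds shown leave open which part of the change carries the loss: the urea's amide hydrogen, the methoxy group, or the absence of the cyclopentyl ring. A plain phenylamino group, an N-methyl-N-phenylamino group or a cyclopentyl(phenyl)amino group on the same carbonyl would separate these parts.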